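A few compounds are considered here, and "the series" means these few. Any claim that something is new, unique, unknown or untested is made for them only; others in the source may bear on it.

Series notes, values in a functional assay on HCT-116 cells (Homo sapiens) for cytotoxicity, read by scintillation counting and thymidine incorporation, with a stated time of 72 h; on this read-out lower numbers stand for stronger inhibition and higher numbers for weaker inhibition:

- compound 1 `COc1cc(OC)cc(C(=CC#N)c2ccc(OC)c(NC(C)=O)c2)c1` gives 92 nM
- compound 2 `CCC=C(c1cc(OC)cc(OC)c1)c1ccc(OC)c(OC)c1` gives > 10000 nM (a limit)
- compound 3 `C=C(c1cc(OC)cc(OC)c1)c1ccc(OC)c(OC)c1` gives > 10000 nM (a limit)

Compound 3 has no number, only a limit. On these data alone, its entry is part of the limit of > 10000 nM in this assay, at which 2 of the 3 values shown sit, so how far it lies from any measurable value is unknown. Compound 2 sits at the same limit.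

The next compound is compound 4 `COc1cc(OC)cc(C(=CC#N)c2ccc(OC)c(OC)c2)c1`. The change from compound 3 is cyano in place of hydrogen on a double-bonded chain carbon bound to a double-bonded chain carbon.

Among the measured compounds shown here, the only step measured between close neighbours, a step that the two limits leave unreadable from compound 2 to compound 3, has no readable size and concerns a different group at this place. The closest guide is therefore compound 1, which carries the cyano group and gives 92 nM. Compound 1 also differs from compound 4 elsewhere on the shared core, so this value is only an approximate guide, and one compound sets no rule.

A large step toward stronger inhibition in this assay is expected, though a result at the limit cannot be excluded. The expected change is an at least 33-fold lower number from compound 3 to compound 4 (1.52 log units; beyond the scatter). For compound 4 the estimate is 300 nM, with an expected range from 40 nM to 3000 nM.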

Compound 4, half-maximal inhibitory concentration: 18 nM
Compound 4: the middle estimate sits 17-fold (1.22 log units) above what was measured; the measured number lies below the stated range.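

In this assay, cyano on a double-bonded chain carbon bound to a double-bonded chain carbon separates a compound with a measured value from compounds with only a limit: the change from hydrogen gives an at least 550-fold lower number from compound 3 to compound 4 (2.74 log units; beyond the scatter), and the change from ethyl gives an at least 550-fold lower number from compound 2 to compound 4 (2.74 log units; beyond the scatter). Both steps are bounds rather than exact sizes, because each starting compound has only a limit: the limit of > 10000 nM in this assay, at which 2 of the 4 values shown sit. With the cyano group kept, methoxy in place of acetamido on an aromatic carbon gives a 5.1-fold lower number from compound 1 to compound 4 (0.71 log units; beyond the scatter), a modest step compared with the two at the chain carbon, which shows that this aromatic place also moves the number.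

The compounds shown leave open whether the gain is particular to cyano, since hydrogen and ethyl are the only other groups at this chain carbon and the step between them cannot be read; a carboxylic acid or an amide there would test this. Also open, on these data alone, is how an amine or a hydroxyl would compare with methoxy and acetamido at the aromatic carbon.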